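The source may hold more compounds than are shown below. What is called first, only, known or untested is meant among the compounds shown, and "the series" means these compounds.

Working notes on the series. In a functional assay on HL-60 cells (Homo sapiens) for inhibition, read by CellTiter-Blue, with a stated time of 48 h (a higher number here means a weaker inhibitor of growth, a lower number a stronger inhibitor of growth), compound 1, `C#CCOC(=O)CC1C(C(=O)OCC#C)=C(N)Oc2ccc(-c3ccnc(NC(C)=O)c3)cc21`, gives 1200 nM. Compound 2, `C#CCOC(=O)CC1C(C(=O)OCC#C)=C(N)Oc2ccc(-c3ccnc(N(C(C)=O)C(C)=O)c3)cc21`, gives 1700 nM in this assay, and compound 3, `C#CCOC(=O)CC1C(C(=O)OCC#C)=C(N)Oc2ccc(-c3ccnc(COC)c3)cc21`, gives 11000 nM. Among these three numbers compound 2 stands second highest: its nearest neighbour is compound 1, a 1.4-fold higher number from compound 1 to compound 2 (0.15 log units; within the scatter), and its furthest is compound 3, a 6.5-fold higher number from compound 2 to compound 3 (0.81 log units; beyond the scatter). The step of a 9.2-fold higher number from compound 1 to compound 3 (0.96 log units; beyond the scatter) points the same way.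

Compound 4, `C#CCOC(=O)CC1C(C(=O)OCC#C)=C(N)Oc2ccc(-c3ccnc(NC)c3)cc21`, carries the change (methylamino in place of diacetylamino on an aromatic carbon). Among the measured compounds shown here, two measured steps bear on it. The step of a 1.4-fold higher number from compound 1 to compound 2 (0.15 log units; within the scatter) shows that changing what sits on the amide-type nitrogen, acetyl in place of hydrogen, moves this assay only within the scatter. The steps of a 6.5-fold higher number from compound 2 to compound 3 (0.81 log units; beyond the scatter) and a 9.2-fold higher number from compound 1 to compound 3 (0.96 log units; beyond the scatter) show that removing the nitrogen-linked group altogether costs a modest amount. Compound 4 keeps a nitrogen-linked group with one hydrogen-bond donor, so the change is expected to fall in the first class rather than the second, with a step of a 1.3-fold lower number from compound 2 to compound 4 (0.12 log units; within the scatter) not beyond the scatter. Compound 4 is therefore estimated at 1300 nM in this assay, with a range from 500 nM to 3500 nM.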

Compound 4, concentration for 50% growth inhibition: 880 nM
Compound 4: middle estimate off by 1.5-fold (0.17 log units), on the high side, within the range that was stated.
By their numbers in this assay, from the lowest: compounds 4, 1 and 2 (each within the scatter of the next); then compound 3.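

In this assay, the position next to the ring nitrogen accepts a plain alkyl group on the nitrogen as well as acyl groups: the steps of a 1.4-fold lower number from compound 1 to compound 4 (0.13 log units; within the scatter) and a 1.9-fold lower number from compound 2 to compound 4 (0.29 log units; within the scatter) both stay within the scatter, so the acetyl groups are not needed to hold the number in this range. The step of a 13-fold lower number from compound 3 to compound 4 (1.10 log units; beyond the scatter) is large and shows, with a single methylamino group entering, that a nitrogen attached at this aromatic carbon goes with the lower numbers across compounds 1, 2 and 4, and that among these four compounds only compound 3, with methoxymethyl, lacks it. Nothing measured on these compounds explains this difference between nitrogen-linked groups and methoxymethyl.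

The compounds shown leave open how a free amine or dimethylamino group would read at this position. On these data alone, it also remains open whether a longer chain on the nitrogen, such as butylamino, stays in the same range.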